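Working notes: cyclopentyl in place of isopropyl

The source may report more compounds than this note shows. Statements on the series, on what has been measured and on what is new or still open speak of the compounds shown alone.

Read-outs so far in a physicochemical assay for solubility (on this read-out lower numbers stand for lower solubility and higher numbers for higher solubility), for the two measured compounds
- compound 1 (`CC(C)Nc1c(C(N)=O)cnn2cc(-c3ccccc3)cc12`) gives < 1 ug/mL as a limit
- compound 2 (`CC(C)CCNc1c(C(N)=O)cnn2cc(-c3ccccc3)cc12`) gives < 1 ug/mL as a limit

Among the compounds with values here, compound 1 stands with a limit and no number, at the limit of < 1 ug/mL in this assay, at which 2 of the 2 values shown sit, for the series so far.

Compound 3 (`NC(=O)c1cnn2cc(-c3ccccc3)cc2c1NC1CCCC1`) is not yet measured. Within the data shown here, it differs from compound 1 by cyclopentyl in place of isopropyl on a nitrogen on an aromatic ring in the place where the one measured step also falls: cyclopentyl in place of isopropyl on a nitrogen on an aromatic ring.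

That measured step is a step that the two limits leave unreadable from compound 1 to compound 2 and both of its ends are limits, so it offers no size to carry over. No step beyond the scatter is expected in this assay and no direction can be given. The expected step is a step that the limit leaves unreadable from compound 1 to compound 3 as estimated here.

Compound 2 also gives < 1 ug/mL as a limit, and this is the ground for expecting compound 3 to give a limit too. The estimated value for compound 3 is 0.5 ug/mL with an expected range from 0.2 ug/mL to 1.2 ug/mL in all likelihood reported only as a limit.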

Compound 3, solubility: < 1 ug/mL
Compound 3 gave a limit, no number (the forecaster's own chance of this, stated with the estimate: 85%); the middle value lies beyond the limit too.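

In this assay compound 3 gives < 1 ug/mL as a limit and not a number, so the steps among compound 1, compound 2 and compound 3 cannot be read. All three values sit at one limit: the limit of < 1 ug/mL in this assay, at which 3 of the 3 values shown sit.

The compounds shown leave open how soluble each compound actually is and whether changing the group on a nitrogen on an aromatic ring alters that solubility.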